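A few compounds are considered here, and "the series" means these few. Any claim that something is new, unique, unknown or untested is made for them only; others in the source may bear on it.

Compound 1, `COc1ccc(-c2cc(=O)c3c(OC)cc(OC)cc3n2S(=O)(=O)c2ccc(F)cc2)cc1`, and compound 2, `COc1ccc(-c2cc(=O)c3c(OC)cc(OC)cc3n2S(=O)(=O)c2ccc(Cl)cc2)cc1`, share one core, while compound 3, `COC(=O)c1cc(=O)c2cc(NC(=O)Nc3ccc(Cl)c(Cl)c3)ccc2[nH]1`, is built on another; the difference between the two cores is not broken down here. In an ADME assay on BJ cells (Homo sapiens) for antiproliferative activity, with a stated time of 72 h (on this read-out higher numbers stand for an effect only at larger amounts of compound and lower numbers for an effect already at smaller amounts), compound 1 reaches only a limit of the assay, > 65500 nM. For compound 2 the result in this assay is also a limit, > 34400 nM. Compound 3 gives in this assay again a limit rather than a number, > 12600 nM.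

The change from compound 2 to compound 1 is fluoro in place of chloro on an aromatic carbon, and the step it makes in this assay is a step that the two limits leave unreadable from compound 2 to compound 1, since both ends are limits. The same kind of change is planned in compound 4, `COC(=O)c1cc(=O)c2cc(NC(=O)Nc3ccc(F)c(Cl)c3)ccc2[nH]1`, which differs from compound 3 by fluoro in place of chloro on an aromatic carbon; here the place is ortho to a chloro group, which the place in compound 1 is not.

Among the compounds with values here, for compound 4 in this assay the expectation is an unreadable step like the one from compound 2 to compound 1, written as a step that the limit leaves unreadable from compound 3 to compound 4, because compound 3 gives only > 12600 nM and no number to start from. Compound 4 is therefore expected to lie around 20000 nM, between 8000 nM and 60000 nM, most likely reported as a limit again.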

Compound 4, half-maximal effective concentration: > 12600 nM
Compound 4 ended at the assay's limit; the forecaster's own chance of this, stated with the estimate: 80%; the middle value does not contradict the limit.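

In this assay, compound 3 and compound 4 both end at a limit of the assay rather than at a number, so no step can be read between them: the limit of > 12600 nM in this assay, at which 2 of the 4 values shown sit.

The compounds shown leave open whether fluoro in place of chloro on an aromatic carbon changes the half-maximal effective concentration at all, on either core.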